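Benzylamide to phenoxyethylamide on a piperidine-carboxamide quinazoline

A few compounds are considered here, and "the series" means these few. Any claim that something is new, unique, unknown or untested is made for them only; others in the source may bear on it.

Compound 1 `COc1cc2nc(N3CCC(C(=O)N4CCOCC4)CC3)nc(N)c2cc1OC` gives 1.14 nM in an assay on isolated protein for displacement of a labelled ligand from Adrenergic receptor alpha-1 (Rattus norvegicus); a lower number here means a stronger inhibitor, a higher number a weaker inhibitor. Compound 2 `COc1cc2nc(N3CCC(C(=O)NCc4ccccc4)CC3)nc(N)c2cc1OC` gives 0.22 nM in this assay.

Compound 2 stands lowest of the two numbers; the nearest is compound 1, from which the step of a 5.2-fold lower number from compound 1 to compound 2 (0.71 log units; beyond the scatter) was seen. Compound 3 `COc1cc2nc(N3CCC(C(=O)NCCOc4ccccc4)CC3)nc(N)c2cc1OC` is not yet measured. It differs from compound 2 by phenoxymethyl in place of phenyl on a saturated chain carbon bound to an amide-type nitrogen. Among the measured compounds shown here, no measured step bears directly on this change: the one step known, a 5.2-fold lower number from compound 1 to compound 2 (0.71 log units; beyond the scatter), exchanged the whole amine part of the amide, whereas here the aromatic ring is kept and only the link between it and the amide nitrogen is lengthened. For the measured compounds named here, with that step as the only guide, a change of modest size at most is expected, with the direction uncertain, and the step of a 1.8-fold higher number from compound 2 to compound 3 (0.26 log units; within the scatter) is therefore estimated as small. For compound 3 the expected value in this assay is 0.4 nM, in the range 0.1 nM to 1.6 nM.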

Compound 3, inhibition constant: 0.42 nM
Compound 3: middle estimate off by 1.1-fold (0.02 log units), on the low side; low and high end bracket the measured number.
By their numbers in this assay, from the lowest: compounds 2 and 3 (each within the scatter of the next); then compound 1.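

In this assay, among the compounds shown here, replacing benzyl with 2-phenoxyethyl on the amide nitrogen, a longer link that also carries an oxygen, gives a 1.9-fold higher number from compound 2 to compound 3 (0.28 log units; within the scatter), so the earlier compounds' single benzyl example now extends to a second, longer group without a difference that can be read. The advantage over the morpholin-4-yl amide also holds for this longer group, with a 2.7-fold lower number from compound 1 to compound 3 (0.43 log units; beyond the scatter) beside a 5.2-fold lower number from compound 1 to compound 2 (0.71 log units; beyond the scatter), so both amides bearing a phenyl ring stand beyond the scatter from compound 1. No evidence is available that explains these results.

As far as these compounds go, whether the aromatic ring matters remains open, and a cyclohexyl group in its place or a plain butyl chain on the amide nitrogen would address that. A 3-phenylpropyl group would separate the effect of the link's length from that of its oxygen.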